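Amide substituent swap on the shared core, efficacy expectation

A few compounds are considered here, and "the series" means these few. Any claim that something is new, unique, unknown or untested is made for them only; others in the source may bear on it.

Of the compounds shown here, two on the shared core have been measured in a functional assay on HEK293 cells for positive allosteric modulation of metabotropic glutamate receptor 5 (Rattus norvegicus), read by fluorescence and calcium flux; a lower number here means a smaller maximal response, a higher number a larger maximal response. Compound 1 `C[C@@H](NC(=O)c1ccc(C#Cc2cc(F)ccn2)cn1)C(C)(C)O` gives 66.2% there. Compound 2 `C[C@@H](NC(=O)c1ccc(C#Cc2cccc(F)c2)cn1)C(C)(C)C` gives 66%, a value that sits within the scatter of compound 1, so the two cannot be told apart on these numbers. For the measured compounds named here, no step between the two measured compounds is recorded, as they differ in more than one place.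

Compound 3 `CC(C)(CO)NC(=O)c1ccc(C#Cc2cccc(F)c2)cn1` has not yet been measured. It departs from compound 2 by 1-(hydroxymethyl)-1-methylethyl in place of 1,2,2-trimethylpropyl on an amide-type nitrogen. The only measured point with an oxygen in the amide substituent is compound 1, and because compound 1 gives 66.2%, a change of this kind has not so far moved the read-out beyond the scatter. The step of a number 1 percentage points lower from compound 2 to compound 3 (within the scatter) is therefore expected to be small, in no firm direction. For compound 3 the expected value in this assay is 65%, with a range from 48% to 82%.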

Compound 3, largest response reached (reported as efficacy), in percent of the reference or control that the assay uses: 60.9%
The estimate for compound 3 lay 4.1 percentage points above the measured number, and the stated range covers the measured number.
By their numbers in this assay, from the lowest: compounds 3, 2 and 1 (each within the scatter of the next).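

In this assay, 1-(hydroxymethyl)-1-methylethyl in place of 1,2,2-trimethylpropyl on an amide-type nitrogen gives a number 5.1 percentage points lower from compound 2 to compound 3 (within the scatter). For the compounds shown here, this is the first single-place comparison at this nitrogen, and it shows that the largest response stays within the scatter when the substituent gains a hydrogen-bond donor and a hydrogen-bond acceptor and loses its defined stereocentre. No supporting data bear on the reason for this outcome.

The compounds shown leave open whether a carboxylic acid or an amine in place of the hydroxymethyl part, or a longer chain on this nitrogen, would also keep the response within the scatter. As far as these compounds go, it also remains open whether the same swap gives a comparable step on the core of compound 1, since this single pair rests on one core.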